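A few compounds are considered here, and "the series" means these few. Any claim that something is new, unique, unknown or untested is made for them only; others in the source may bear on it.

Measured so far:
Compound 1, `COC(=O)c1cc(-c2cccc(NC(=O)c3ccc(/C=C/C(=O)c4cccc(C(F)(F)F)c4)cc3)c2)on1`, gives > 20 ug/mL.
Compound 2, `COC(=O)c1cc(-c2cccc(NC(=O)c3ccc(/C=C/C(=O)c4ccc([N+](=O)[O-])cc4)cc3)c2)on1`, gives > 20 ug/mL.

Both numbers come from an ADME assay on Vero cells (Chlorocebus sabaeus) for cytotoxicity, read by MTT assay, with a stated time of 72 h; on this read-out lower numbers stand for higher toxicity in this test and higher numbers for lower toxicity in this test. The value of compound 1 is a limit of the test and not a number. The value of compound 2 is likewise a limit, not a number. As a result, a step that the two limits leave unreadable from compound 1 to compound 2 cannot be sized, because of the limit of > 20 ug/mL in this assay, at which 2 of the 2 values shown sit.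

Compound 3, `COC(=O)c1cc(-c2cccc(NC(=O)c3ccc(/C=C/C(=O)c4cccc([N+](=O)[O-])c4)cc3)c2)on1`, is the next candidate. Compared with compound 2 the change is 3-nitrophenyl in place of 4-nitrophenyl on a carbonyl carbon. Within the data shown here, the only measured step that touches this part of the molecule is the one from compound 1 to compound 2, and its size is not readable. There is thus no basis for expecting a step beyond the scatter in this assay in either direction. Compound 3 is therefore expected to give about 30 ug/mL, within 10 ug/mL to 100 ug/mL. This expectation means a step that the limit leaves unreadable from compound 2 to compound 3, and most likely the test again reports only a limit.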

Compound 3, half-maximal cytotoxic concentration: > 40 ug/mL
Compound 3 ended at the assay's limit; the forecaster's own chance of this, stated with the estimate: 80%; at least 1.3-fold (0.12 log units) between middle value and limit.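

Among these compounds, the results for compound 1, compound 2 and compound 3 in this assay are all limits and not numbers, so no step among them can be read. Still open, going by these compounds, is whether 3-nitrophenyl in place of 4-nitrophenyl, or nitro in place of trifluoromethyl, changes the read-out at all.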